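From Cyclopropyl to Oxan-4-yl: Plasma Protein Binding Expected

A few compounds are considered here, and "the series" means these few. Any claim that something is new, unique, unknown or untested is made for them only; others in the source may bear on it.

Compound 2, `CCn1ncc(-c2nc3c(O[C@H]4CCN(C(=O)C5CC5)C4)ncnc3n2C)c1C`: 67%
Compound 1, `CCn1ncc(-c2nc3c(N4CCC(n5c(=O)[nH]c6ncccc65)CC4)ncnc3n2C)c1C`: 90%

In an ADME assay on a cell-free system (plasma, Rattus norvegicus, strain Wistar Han) for protein binding, compound 2 gives 67%, the highest unbound fraction of the two measured compounds. Compound 1 gives 90%, an unbound fraction lower than that of compound 2 by a gap beyond the scatter. Compound 3, `CCn1ncc(-c2nc3c(O[C@H]4CCN(C(=O)C5CCOCC5)C4)ncnc3n2C)c1C`, differs from compound 2 by oxan-4-yl in place of cyclopropyl on a carbonyl carbon. Within the data shown here, no measured pair shows this change, so the step from compound 2 to compound 3 is expected to be small, a 1.2-fold higher unbound fraction from compound 2 to compound 3 (0.06 log units; within the scatter), toward slightly less binding or none beyond the scatter. Compound 3 is therefore estimated at 62%, within 45% to 78%.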

Compound 3, plasma protein binding: 27%
The estimate for compound 3 lay 1.9-fold (0.28 log units) (unbound fraction) below the measured number; measured number below the stated range.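

On this carbonyl carbon, the group is not a silent part of the molecule in this assay: oxan-4-yl in place of cyclopropyl gives a 2.2-fold higher unbound fraction from compound 2 to compound 3 (0.34 log units; beyond the scatter). This is the only step shown at this position, and it shifts compound 3 toward the free form. Nothing available explains the size of this step. Oxan-4-yl differs from cyclopropyl in both ring size and ring oxygen, and the compounds shown do not separate the two. They also leave open how cyclohexyl or a piperidin-4-yl amine would behave on this carbonyl carbon.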